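Nitro for methoxy on the sulfonate aryl ring, second core

This account rests on a few compounds, and the source may have more. Where it says the series, first, only, none or still open, it means among the compounds named here.

Three measured compounds share one scaffold and are read in a functional assay on HL-60 cells (Homo sapiens) for inhibition, read by CCK-8 assay, with a stated time of 48 h, tested at 20 uM; a higher number here means more inhibition of growth at the concentration tested, a lower number less inhibition of growth. Compound 1 `COc1ccc(S(=O)(=O)Oc2ccccc2/C=C(\C#N)C(=O)Nc2nnc(Cc3ccc(F)cc3)s2)cc1` gives 100%. Compound 2 `N#C/C(=C\c1ccccc1OS(=O)(=O)c1ccc([N+](=O)[O-])cc1)C(=O)Nc1nnc(Cc2ccc(F)cc2)s1` gives 18%, and the change from compound 1 to compound 2, (nitro in place of methoxy on an aromatic carbon), costs a number 82 percentage points lower from compound 1 to compound 2 (beyond the scatter). Compound 3 `COc1ccc(S(=O)(=O)Oc2ccccc2/C=C(\C#N)C(=O)Nc2nnc(Cc3ccc(Cl)cc3)s2)cc1` gives 99%; it differs from compound 1 by chloro in place of fluoro on an aromatic carbon, a step of a number 1 percentage points lower from compound 1 to compound 3 (within the scatter).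

Compound 4 `N#C/C(=C\c1ccccc1OS(=O)(=O)c1ccc([N+](=O)[O-])cc1)C(=O)Nc1nnc(Cc2ccc(Cl)cc2)s1` is not yet measured. It differs from compound 3 by nitro in place of methoxy on an aromatic carbon, the same change that separates compound 2 from compound 1, at the same place. The two cores differ only by chloro in place of fluoro on an aromatic carbon, and that exchange left the read-out unchanged within scatter.

For the measured compounds named here, since compound 3 stands where compound 1 stands, the step to compound 4 in this assay is expected to be about as large as the earlier one, and is estimated at a number 79 percentage points lower from compound 3 to compound 4 (beyond the scatter), resting on the single observed step of a number 82 percentage points lower from compound 1 to compound 2 (beyond the scatter). Compound 4 is therefore expected to give about 20%, plausibly between 5% and 45%.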

Compound 4, percent growth inhibition at one concentration: 34%
Compound 4: the middle estimate sits 14 percentage points below what was measured, within the range that was stated.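

In this assay, nitro in place of methoxy again gives a large loss of growth inhibition on the chloro core, a number 65 percentage points lower from compound 3 to compound 4 (beyond the scatter), so the direction of the change carries from one core to the other, but its size does not carry exactly: the same change on two cores in this assay, a number 82 percentage points lower (beyond the scatter) from compound 1 to compound 2 and a number 65 percentage points lower (beyond the scatter) from compound 3 to compound 4, 17 percentage points apart, beyond the scatter of two such steps
Read the other way, chloro in place of fluoro gives a number 16 percentage points higher from compound 2 to compound 4 (beyond the scatter) between the two nitro compounds, so the effect of this exchange depends on which group sits on the sulfonate aryl ring: the same change on two cores in this assay, a number 1 percentage points lower (within the scatter) from compound 1 to compound 3 and a number 16 percentage points higher (beyond the scatter) from compound 2 to compound 4, 17 percentage points apart, beyond the scatter of two such steps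
These four compounds show a large loss on both cores, but they give no reason for the gap in size and do not show how the change would behave on any other core.

From the compounds shown here alone, the sulfonate aryl ring carries only methoxy or nitro here, so it remains open how an amine, a methyl or a trifluoromethyl group at that place would read. The halogen site likewise holds only fluoro and chloro, leaving bromo or methyl open.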